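Swapping a phenyl for furan-2-yl on the shared core

The compounds below may be only part of what the source reports. "The series", "measured", "known", "first", "only" and "open" are said of these compounds alone.

Measured compounds: compound 1 `O=C(Cn1c(-c2ccccc2)cc(-c2ccccc2)c1-c1ccco1)Nc1nc2ccccc2s1`, 89.9%; compound 2 `O=C(Cn1c(-c2ccccc2)cc(-c2ccccc2)c1-c1ccco1)Nc1ccccn1`, 69.4%; compound 3 `O=C(Cn1c(-c2ccccc2)cc(-c2ccccc2)c1-c1ccccc1)Nc1ccccn1`, 62.9%.

In an ADME assay on HEK-293T cells (Homo sapiens) for cytotoxicity, read by MTT assay, with a stated time of 72 h, tested at 50 uM (a lower number here means less inhibition, a higher number more inhibition at the concentration tested (going by the name of the read-out)), compound 1 gives the highest number of the three. The step of a number 20.5 percentage points lower from compound 1 to compound 2 (beyond the scatter) exchanges the group on the amide-type nitrogen. The step of a number 6.5 percentage points higher from compound 3 to compound 2 (within the scatter) is the change (furan-2-yl in place of phenyl on an aromatic carbon). The difference between the cores of compound 1 and compound 3 is not broken down here.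

Compound 4 `O=C(Cn1c(-c2ccccc2)cc(-c2ccco2)c1-c1ccco1)Nc1nc2ccccc2s1` is not yet measured. It differs from compound 1 by furan-2-yl in place of phenyl on an aromatic carbon. This is the same kind of change as in compound 3 to compound 2, but at a different place: there the changed carbon is next to the ring nitrogen, here it is two ring bonds from the ring nitrogen. Because a number 6.5 percentage points higher from compound 3 to compound 2 (within the scatter) stayed within the scatter, the step of a number 0.1 percentage points higher from compound 1 to compound 4 (within the scatter) is expected to be small as well. Compound 4 is estimated at 90% in this assay, between 78% and 98%.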

Compound 4, a percentage reported as inhibition, at one concentration (the size of the read-out at that concentration, not a potency): 65.1%
For compound 4 the middle estimate is 24.9 percentage points above the measured one; measured number outside the range, below it.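

Putting furan-2-yl in place of phenyl gives a number 24.8 percentage points lower from compound 1 to compound 4 (beyond the scatter) in this assay. The size of this change therefore did not carry over from one core to the other: the same change on two cores in this assay, a number 6.5 percentage points higher (within the scatter) from compound 3 to compound 2 and a number 24.8 percentage points lower (beyond the scatter) from compound 1 to compound 4, 31.3 percentage points apart, beyond the scatter of two such steps

This does not show why, since the two steps differ both in the group on the amide-type nitrogen, pyridin-2-yl against 1,3-benzothiazol-2-yl, and in which carbon is changed, here the one two ring bonds from the ring nitrogen, so neither difference can be singled out.

From the compounds shown here alone, whether the same change at this carbon would give a similar step with pyridin-2-yl on the amide-type nitrogen remains open. So does the effect of an amine or a carboxylic acid at that carbon in this assay.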